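The source may report more compounds than this note shows. Statements on the series, on what has been measured and on what is new or still open speak of the compounds shown alone.

Of the compounds shown here, two of a shared core have been measured. Compound 1 `Cc1nc(COc2ccc(/C=C3\SC(=O)NC3=O)cc2)cs1` was tested in a functional assay on the whole organism (plasma, strain Wistar) with Rattus norvegicus as the target, with a stated time of 15 days, at a dose of 30 mg/kg by the oral route (on this read-out lower numbers stand for a weaker effect and higher numbers for a stronger effect at the one dose given), where compound 1 gives 14.7%. Compound 2 `O=C1NC(=O)/C(=C/c2ccc(OCCSc3nnc(-c4ccccc4)[nH]3)cc2)S1` carries a different side chain on the same core; in this assay compound 2 gives 14.7%. On the digits reported, compound 2 stands level with compound 1, and the two values lie within the usual scatter of each other, so nothing separates them here.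

The next compound, compound 3 `Cc1ccc(-c2nnc(SCCOc3ccc(/C=C4\SC(=O)NC4=O)cc3)[nH]2)cc1`, is not yet measured. It differs from compound 2 in a single place: methyl in place of hydrogen on an aromatic carbon. Read one bond further out, the change turns a phenyl into a 4-methylphenyl. Among the measured compounds shown here, no step between two measured compounds shows what such a small addition does on this read-out, so the only anchor is the value of compound 2.

With that anchor, the expected step from compound 2 to compound 3 in this assay is a number 0.3 percentage points higher from compound 2 to compound 3 (within the scatter), that is, none beyond the scatter. Compound 3 is therefore estimated to give 15% in this assay, within a range from 4% to 28%.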

Compound 3, a percentage reported as activity, at one dose (the size of the read-out at that dose, not a potency): 22.6%
For compound 3 the middle estimate is 7.6 percentage points below the measured one; the range from low to high includes it.
By their numbers in this assay, from the lowest: compounds 1, 2 and 3 (each within the scatter of the next).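

Among the compounds shown here, this is the first step in this assay that isolates a single small change: methyl in place of hydrogen on an aromatic carbon, para to a large group, which turns a phenyl into a 4-methylphenyl. The step is a number 7.9 percentage points higher from compound 2 to compound 3 (within the scatter), so on this read-out the added methyl does not separate the two compounds, something that compounds 1 and 2, which differ in a whole side chain, could not show for this position. No supporting data bear on this result, so it cannot be said what lies behind the step or whether it would hold up on repeated measurement.

The compounds shown leave open whether a larger or different group at this same place, such as an ethyl, a methoxy, a chlorine atom or a carboxylic acid, would give a step beyond the scatter. They also leave open whether a methyl elsewhere on this ring would read the same way, and how any of these compounds would behave at other doses, since only one dose is reported.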